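Trifluoromethyl for bromo on the core of compound 1

The source may hold more compounds than are shown below. What is called first, only, known or untested is meant among the compounds shown, and "the series" means these compounds.

Compound 1 `O=c1[nH]c(=O)n([C@H]2C[C@H](O)[C@@H](COP(=O)(O)O)O2)cc1Br` is measured in a functional assay on L1210 cells (Mus musculus) for antiproliferative activity (on this read-out lower numbers stand for stronger inhibition and higher numbers for weaker inhibition), at 34.6 ug/mL, the higher of the two numbers present. For the measured compounds named here, compound 2 `O=c1[nH]c(=O)n([C@H]2C[C@@H]3O[PH](O)(O)OC[C@H]3O2)cc1F` gives in this assay a far lower value, 0.06 ug/mL, a gap beyond the usual scatter; no single-change step links these two. Compound 3 `O=c1[nH]c(=O)n([C@H]2C[C@@H]3OP(=O)(OCc4ccccc4)OC[C@H]3O2)cc1I` reaches in this assay only the limit of the assay, > 100 ug/mL. The unmeasured compound 4 `O=c1[nH]c(=O)n([C@H]2C[C@H](O)[C@@H](COP(=O)(O)O)O2)cc1C(F)(F)F` departs from compound 1 by trifluoromethyl in place of bromo on an aromatic carbon. Going by the values given here, no measured step of this kind exists, so its size is open; the expectation is a move to lower numbers beyond the scatter. Compound 4 is expected in this assay near 1.5 ug/mL, within 0.15 ug/mL to 15 ug/mL, an expected step of a 23-fold lower number from compound 1 to compound 4 (1.36 log units; beyond the scatter).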

Compound 4, concentration for 50% inhibition: 0.017 ug/mL
The estimate for compound 4 lay 88-fold (1.95 log units) above the measured number, outside the stated range (below it).
By their numbers in this assay, from the lowest: compound 4; then compound 2; then compound 1. At a limit, above all of these: compound 3.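

In this assay, the group on this aromatic carbon of the core of compound 1 strongly controls the read-out: trifluoromethyl in place of bromo gives a 2000-fold lower number from compound 1 to compound 4 (3.31 log units; beyond the scatter). For the compounds shown here, this is the first single-change step, so this exchange alone accounts for the shift, with the rest of the structure held constant. Nothing measured on these compounds explains the size of the step.

On these data alone, whether a nitrile, a methyl or an ethyl group here would give a similarly low number remains open. So does whether the same exchange would produce a comparable step on the other cores shown.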